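A few compounds are considered here, and "the series" means these few. Any claim that something is new, unique, unknown or untested is made for them only; others in the source may bear on it.

Measured so far: compound 1 `COc1cccc(CCCNC(C)=O)c1` with 23.3 nM and compound 2 `COc1ccc(O)c(CCCNC(C)=O)c1` with 379 nM.

In an assay on CHO cells for displacement of a labelled ligand from melatonin receptor type 1A (Homo sapiens), read by scintillation counting, with a stated time of 60 min (on this read-out higher numbers stand for weaker inhibition and lower numbers for stronger inhibition), compound 2 stands highest of the two numbers, and the single shown step, a 16-fold higher number from compound 1 to compound 2 (1.21 log units; beyond the scatter), is large and beyond the scatter. Compound 3 `CCOc1ccc(OC)cc1CCCNC(C)=O` differs from compound 2 by ethyl in place of hydrogen on an oxygen on an aromatic ring. No step for ethoxy is shown, so only that hydroxy step bears on it. Compound 3 is expected to recover part of that loss, giving a step of a 4.7-fold lower number from compound 2 to compound 3 (0.68 log units; beyond the scatter). Compound 3 is therefore estimated at 80 nM, within a range of 20 nM to 400 nM.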

Compound 3, inhibition constant: 183 nM
For compound 3 the middle estimate is 2.3-fold (0.36 log units) below the measured one; low and high end bracket the measured number.
By their numbers in this assay, from the lowest: compound 1; then compound 3; then compound 2.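

In this assay, ethyl on the oxygen of compound 2 wins back only part of the loss, with a 2.1-fold lower number from compound 2 to compound 3 (0.32 log units; beyond the scatter). Ethoxy still falls short of plain hydrogen at this aromatic carbon, with a 7.9-fold higher number from compound 1 to compound 3 (0.90 log units; beyond the scatter), so the cost of substitution here is not limited to the free hydroxy. Nothing available explains either shift.

Still open, going by these compounds, is whether a longer alkoxy chain would move the number further in the same direction, and whether an amine or a fluorine at this position would come closer to compound 1.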